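A few compounds are considered here, and "the series" means these few. Any claim that something is new, unique, unknown or untested is made for them only; others in the source may bear on it.

Measured compounds:
- compound 1, `O=C(C[C@H](CCN1CCCCC1)NC(=O)c1cc(-c2cccs2)n(C2CCCC2)n1)NC1CCC1`: "nd" (no result reported) in an ADME assay on microsomes from liver (Rattus norvegicus, strain Sprague-Dawley) for metabolic stability, read by LC-MS, using NADPH, with a stated time of 30 min, tested at 1 uM; on this read-out higher numbers stand for a more stable compound and lower numbers for a less stable compound
- compound 2, `O=C(C[C@H](CCN1CCCCC1)NC(=O)c1cc(-c2ccccc2C(F)(F)F)n(C2CCCC2)n1)NC1CCC1`: 74.6%

Going by the values given here, compound 2 is the only entry with a number in this assay; compound 1 carries no result, so nothing can be said about a step between them. Among the compounds with values here, on the single value available, compound 2 stands as the reference point with 74.6% remaining.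

Compound 3, `CN(CC[C@@H](CC(=O)NC1CCC1)NC(=O)c1cc(-c2ccccc2C(F)(F)F)n(C2CCCC2)n1)C1CCCCC1`, is not yet measured. Its difference from compound 2 is cyclohexyl(methyl)amino in place of piperidin-1-yl on a saturated chain carbon, three bonds along the chain from an amide-type nitrogen. Within the data shown here, with no measured pair to calibrate the step, the expectation rests only on the size of the change: a ring with one hetero atom is replaced by a carbon-only ring with two further heavy atoms. A small decrease in this assay is expected, probably close to the scatter rather than well beyond it; the estimated step is a number 12.6 percentage points lower from compound 2 to compound 3 (beyond the scatter). Compound 3 is therefore estimated at 62%, with a range from 38% to 84%.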

Compound 3, percent of the compound remaining: 65.2%
Compound 3: the middle estimate sits 3.2 percentage points below what was measured; the range from low to high includes it.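

In this assay, going by these compounds alone, the exchange of piperidin-1-yl for cyclohexyl(methyl)amino on a saturated chain carbon, three bonds along the chain from an amide-type nitrogen, gives a number 9.4 percentage points lower from compound 2 to compound 3 (within the scatter) and provides the first readable step. On this single pair, the position accepts a group of 8 heavy atoms with a six-membered ring of carbon only, with no separation from compound 2 beyond the usual scatter. Nothing measured on these compounds explains the step.

From the compounds shown here alone, whether a dimethylamino group, a morpholin-4-yl group or a longer chain carrying piperidin-1-yl would give a similar reading at this place remains open. Within the data shown here, the one step also cannot separate the part played by the cyclohexyl ring from that of the methyl group on the same nitrogen.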